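A few compounds are considered here, and "the series" means these few. Any claim that something is new, unique, unknown or untested is made for them only; others in the source may bear on it.

Measured so far:
Compound 1 `COc1cc(-c2nc(SCc3cn(CC(=O)NC(=O)Nc4ccccn4)nn3)nc(Nc3ccc(C(C)C)cc3)c2C#N)cc(OC)c1OC`: 35500 nM
Compound 2 `Cc1ccc(-c2nc(SCc3cn(CC(=O)NC(=O)Nc4ccccn4)nn3)nc(Nc3ccc(C(C)C)cc3)c2C#N)cc1`: 19300 nM
Compound 3 `Cc1ccc(Nc2nc(SCc3cn(CC(=O)NC(=O)Nc4ccccn4)nn3)nc(-c3ccc(Br)cc3)c2C#N)cc1`: 13900 nM

In a functional assay on MGC-803 cells (Homo sapiens) for inhibition, read by MTT assay, with a stated time of 72 h (a higher number here means a weaker inhibitor, a lower number a stronger inhibitor), compound 3 shows the smallest of the three numbers; its gap to compound 2 lies within the scatter, while compound 1 stands beyond it. Within the data shown here, the only single-point step measured so far, a 1.8-fold lower number from compound 1 to compound 2 (0.26 log units; within the scatter), changed a different part of the shared core and does not bear on the present change. Compound 4 `CC(C)c1ccc(Nc2nc(SCc3cn(CC(=O)NC(=O)Nc4ccccn4)nn3)nc(-c3ccc(Br)cc3)c2C#N)cc1` differs from compound 3 by isopropyl in place of methyl on an aromatic carbon. Compounds 2 and 3 differ in two places at once, so their values offer no clean guide either. Among the measured compounds shown here, with no directly comparable step, no change beyond the scatter is expected, and the step of a 1.2-fold lower number from compound 3 to compound 4 (0.06 log units; within the scatter) is my estimate. Compound 4 is therefore expected to give about 12000 nM, within 5000 nM to 30000 nM.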

Compound 4, half-maximal inhibitory concentration: 15600 nM
Compound 4: middle estimate off by 1.3-fold (0.11 log units), on the low side; low and high end bracket the measured number.
By their numbers in this assay, from the lowest: compounds 3, 4, 2 and 1 (each within the scatter of the next, the first and the last beyond it).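

In this assay the step from (4-methylphenyl)amino to (4-isopropylphenyl)amino gives a 1.1-fold higher number from compound 3 to compound 4 (0.05 log units; within the scatter) and so shows that this position accepts isopropyl as readily as methyl. With the bromo group, a 1.2-fold lower number from compound 2 to compound 4 (0.09 log units; within the scatter) also stays within the scatter, whereas 4-bromophenyl in place of 3,4,5-trimethoxyphenyl gives a 2.3-fold lower number from compound 1 to compound 4 (0.36 log units; beyond the scatter) as a modest step beyond it. No measurement is available to explain these steps. Still open, from the compounds shown here alone, is how an amine or a carboxylic acid at this position would behave, and whether a longer chain such as hexyl would change the number.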